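This account rests on a few compounds, and the source may have more. Where it says the series, first, only, none or still open, it means among the compounds named here.

Measured in a functional assay on LOX IMVI cells (Homo sapiens) for cytotoxicity, read by MTT assay, with a stated time of 24 h; a higher number here means a weaker inhibitor, a lower number a stronger inhibitor:
- compound 1 `COc1ccc(S(=O)(=O)NCCCNc2nccc(-c3[nH]c(-c4ccccc4)nc3-c3ccc(F)c(OC)c3)n2)cc1`: 6130 nM
- compound 2 `COc1cc(-c2nc(-c3ccccc3)[nH]c2-c2ccnc(NCCCNS(=O)(=O)c3ccc(Br)cc3)n2)ccc1Cl`: 23700 nM
- compound 3 `COc1cc(-c2nc(-c3ccccc3)[nH]c2-c2ccnc(NCCCNS(=O)(=O)c3ccc(C)cc3)n2)ccc1Cl`: 18600 nM

Compound 3, at 18600 nM, stands at the upper end of these three numbers together with compound 2, from which it is not separated beyond the scatter. Compound 1 lies clearly lower than both.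

The next compound, compound 4 `COc1ccc(S(=O)(=O)NCCCNc2nccc(-c3[nH]c(-c4ccccc4)nc3-c3ccc(Cl)c(OC)c3)n2)cc1`, has not yet been measured. It takes compound 3 and puts methoxy in place of methyl on an aromatic carbon, para to a large group (methoxy in place of methyl on an aromatic carbon).

Going by the values given here, the only measured step at this place is a 1.3-fold lower number from compound 2 to compound 3 (0.11 log units; within the scatter), with methyl in place of bromo, and it stays within the scatter. A second hint comes from the methoxy group itself. Compound 4 shares it with compound 1, which carries fluoro where compound 4 carries chloro, and compound 1 gives 6130 nM. The data cannot separate the effects of those two differences, so this hint counts only weakly and leans toward a lower number.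

The expected step is a 1.3-fold lower number from compound 3 to compound 4 (0.12 log units; within the scatter), and no change beyond the scatter is anticipated with any confidence. The estimate for compound 4 is 14000 nM, with an expected range from 7000 nM to 26000 nM.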

Compound 4, half-maximal inhibitory concentration: 1800 nM
Compound 4: the middle estimate sits 7.8-fold (0.89 log units) above what was measured; measured number below the stated range.
By their numbers in this assay, from the lowest: compound 4; then compound 1; then compounds 3 and 2 (each within the scatter of the next).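

In this assay, the place on the sulfonyl-bearing ring had so far shown only a 1.3-fold lower number from compound 2 to compound 3 (0.11 log units; within the scatter), which suggested that it tolerated a change of group without much effect. With methoxy there, the picture changes: the 4-methylphenyl to 4-methoxyphenyl change gives a 10-fold lower number from compound 3 to compound 4 (1.01 log units; beyond the scatter), and methoxy in place of bromo gives a 13-fold lower number from compound 2 to compound 4 (1.12 log units; beyond the scatter), so this place does respond, and methoxy separates from both methyl and bromo in a way those two do not separate from each other. The second place also counts, though less, since chloro in place of fluoro on the other aromatic ring, with the 4-methoxyphenyl group kept, gives a 3.4-fold lower number from compound 1 to compound 4 (0.53 log units; beyond the scatter), and nothing available accounts for either effect.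

The compounds shown leave open whether the gain is particular to methoxy or would extend to other groups at that place, such as an ethoxy, a hydroxyl or an amine. They also do not tell whether the chloro and fluoro step would keep its size with 4-methylphenyl in place of 4-methoxyphenyl, or how a longer chain in place of the present linker would affect these numbers.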